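Crown ether esters: replacing the cyclopropyl acid with phenylbutanoate

The compounds below may be only part of what the source reports. "The series", "measured", "known", "first", "only" and "open" are said of these compounds alone.

Compound 1 `CC(C)=CC1C(C(=O)OCC2COCCOCCOCCOCCOCCO2)C1(C)C` carries a cyclopropane ester on the crown ether core. In a functional assay on SW1573 cells (Homo sapiens) for inhibition, read by sulforhodamine B assay, with a stated time of 48 h (on this read-out higher numbers stand for weaker inhibition of growth and lower numbers for stronger inhibition of growth), compound 1 gives 54000 nM, the higher of the two numbers recorded; compound 2 `O=C(OCC1COCCOCCOCCOCCOCCO1)c1cccc(-c2ccc(Br)cc2)c1` gives 4400 nM, a gap beyond the usual scatter. Compound 3 `O=C(CCCCc1ccccc1)OCC1COCCOCCOCCOCCOCCO1` differs from compound 1 by 4-phenylbutyl in place of 2,2-dimethyl-3-(2-methylprop-1-en-1-yl)cyclopropyl on a carbonyl carbon. Going by the values given here, no measured pair isolates this change, so compound 3 is estimated with moderate confidence: a step toward stronger growth inhibition in a 2.7-fold lower number from compound 1 to compound 3 (0.43 log units; beyond the scatter) seems likely, but not beyond the scatter with certainty. For compound 3 the expected value in this assay is 20000 nM, within 6000 nM to 60000 nM.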

Compound 3, concentration for 50% growth inhibition: > 100000 nM
Compound 3: only a limit was reported; the forecaster's own chance of this, stated with the estimate: 10%; middle value at least 5.0-fold (0.69 log units) from the limit.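

Compound 3 is recorded in this assay only as a limit, > 100000 nM. On the carbonyl carbon, 4-phenylbutyl in place of 2,2-dimethyl-3-(2-methylprop-1-en-1-yl)cyclopropyl gives an at least 1.8-fold higher number from compound 1 to compound 3 (0.26 log units; that floor lies within the scatter), so this change shows no gain in growth inhibition, while the floor alone does not separate the two compounds. The true size of the step remains unknown because the reading stops at the limit: the limit of > 100000 nM in this assay, at which 1 of the 3 values shown sits.

Open, as far as these compounds go, is how a longer chain ending in phenyl would read at this position. Also open, from the compounds shown here alone, is whether an amine or a carboxylic acid at the chain end would bring a measurable number.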